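This account rests on a few compounds, and the source may have more. Where it says the series, first, only, none or still open, it means among the compounds named here.

Compound 1 `C=C1C(=O)[C@@]23C(=O)OC[C@]4(C(=O)CCC(C)(C)[C@H]4C=O)[C@@H]2CC[C@@H]1[C@H]3OC(=O)c1ccc(OC)cc1` - 1870 nM
Compound 2 `C=C1C(=O)[C@@]23C(=O)OC[C@]4(C(=O)CCC(C)(C)[C@H]4C=O)[C@@H]2CC[C@@H]1[C@H]3OC(=O)c1ccc(F)cc1` - 3960 nM

In a functional assay on MGC-803 cells (Homo sapiens) for cytotoxicity, read by MTT assay, with a stated time of 72 h (a higher number here means a weaker inhibitor, a lower number a stronger inhibitor), compound 2 at 3960 nM holds the higher of the two numbers, which makes it the weaker inhibitor of this pair. Compound 3 `C=C1C(=O)[C@@]23C(=O)OC[C@]4(C(=O)CCC(C)(C)[C@H]4C=O)[C@@H]2CC[C@@H]1[C@H]3OC(=O)c1ccccc1F` keeps the shared core and carries 2-fluorophenyl in place of 4-fluorophenyl on a carbonyl carbon. Among the measured compounds shown here, only one measured step offers any guide: a 2.1-fold higher number from compound 1 to compound 2 (0.33 log units; beyond the scatter) is a modest change, seen with fluoro in place of methoxy on an aromatic carbon. For the measured compounds named here, no measured pair compares 2-fluorophenyl with 4-fluorophenyl, so the data point in neither direction. Going by the modest size of that one step, the expected change is small, a 1.1-fold lower number from compound 2 to compound 3 (0.05 log units; within the scatter) by estimate, and probably no larger than the scatter. For compound 3 the estimated value is 3500 nM with an expected range (1500 nM to 8500 nM).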

Compound 3, half-maximal inhibitory concentration: 3940 nM
Compound 3: the middle estimate sits 1.1-fold (0.05 log units) below what was measured; low and high end bracket the measured number.
By their numbers in this assay, from the lowest: compound 1; then compounds 3 and 2 (each within the scatter of the next).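

Placing 2-fluorophenyl in place of 4-fluorophenyl on this carbonyl carbon gives a 1.0-fold lower number from compound 2 to compound 3 (0.00 log units; within the scatter) in this assay, so this assay does not tell these two placements of the fluorine apart. The step of 2-fluorophenyl in place of 4-methoxyphenyl, a 2.1-fold higher number from compound 1 to compound 3 (0.32 log units; beyond the scatter), is modest but beyond the scatter, which leaves compound 1 the strongest of the three, with both fluorophenyl compounds on the weaker side. No separate measurement is available to explain any of these numbers.

Going by these compounds, with only these three compounds, it remains open whether the methoxy group itself matters or whether any other group on the aromatic ring would do as well. An amine or a carboxylic acid on that ring, or a longer chain in place of the ring, could shift the number in either direction.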